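Hydrazone replacement on a pyrazole carboxamide: expected antiproliferative potency

This account rests on a few compounds, and the source may have more. Where it says the series, first, only, none or still open, it means among the compounds named here.

Compound 1, `O=C(N/N=C/c1ccc(F)cc1F)c1cc(-c2ccc(Cl)cc2)nn1Cc1ccc(Cl)nc1`, gives 7860 nM in a functional assay on NCI-H23 cells (Homo sapiens) for antiproliferative activity, read by BrdU incorporation, with a stated time of 48 h; on this read-out higher numbers stand for weaker inhibition and lower numbers for stronger inhibition.
Compound 2, `CC(C)(C)c1ccc(Cn2nc(-c3ccc(Cl)cc3)cc2C(=N)NO)cc1`, gives 12300 nM in this assay.
Compound 3, `CC(C)(C)c1ccc(Cn2nc(-c3ccc(Cl)cc3)cc2/C(N)=N/OC(=O)c2cccc(O)c2O)cc1`, gives 15600 nM in this assay.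

Of the three measured compounds, compound 1 carries the lowest number, but its distance to compound 2 and its distance to compound 3 both lie within the usual scatter of repeated measurements, so the three cannot be told apart on these figures alone. Compound 2 and compound 3 also share a different substituent on the core nitrogen, so no single-point comparison to compound 1 is available among the measured set.

Compound 4, `N#Cc1ccc(/C=N/NC(=O)c2cc(-c3ccc(Cl)cc3)nn2Cc2ccc(Cl)nc2)cc1`, has not been measured. It differs from compound 1 in one place: 4-cyanophenyl in place of 2,4-difluorophenyl on a carbon with a double bond to nitrogen. Going by the values given here, no measured pair in this set isolates this kind of change, so there is no observed step to lean on. In the absence of such a step, the account expects the change to produce no step beyond the scatter, and the estimate therefore treats compound 4 as lying close to compound 1. The expected step from compound 1 to compound 4 is a 1.1-fold lower number from compound 1 to compound 4 (0.05 log units; within the scatter). Compound 4 is expected to give about 7000 nM, within a range of 2500 nM to 20000 nM.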

Compound 4, half-maximal inhibitory concentration: > 100000 nM
Compound 4: no number, only a limit (the forecaster's own chance of this, stated with the estimate: 10%); middle value at least 14-fold (1.15 log units) from the limit.
By their numbers in this assay, from the lowest: compounds 1, 2 and 3 (each within the scatter of the next). At a limit, above all of these: compound 4.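

Compounds 1, 2 and 3 could not be told apart and gave no view of the aryl group on a carbon with a double bond to nitrogen, but this position now proves sensitive: 4-cyanophenyl in place of 2,4-difluorophenyl brings an at least 12-fold higher number from compound 1 to compound 4 (1.10 log units; beyond the scatter). In this assay, compound 4 has a limit of the assay and not a number, so the full size of the step stays unknown: the limit of > 100000 nM in this assay, at which 1 of the 4 values shown sits.

The change is a narrow one, since both groups have the same heavy-atom count and each is a six-membered aromatic ring of carbon only, yet the shared core with this group exchanged does not keep the activity of compound 1.

The compounds shown leave open whether the step goes with the nitrile that enters or with the two fluorines that leave, and nothing here gives a cause for it. A plain phenyl or a 4-fluorophenyl group at this place would help separate these two readings, and a 4-cyano-2-fluorophenyl group would show whether a fluorine kept alongside the nitrile restores a measurable value.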